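Compound 3 to compound 4: cyclohexylcarbonyl leaves the core

The source may report more compounds than this note shows. Statements on the series, on what has been measured and on what is new or still open speak of the compounds shown alone.

In a physicochemical assay for solubility, read by chemiluminescence, measured as kinetic solubility (a higher number here means a more soluble compound, a lower number a less soluble compound), compound 1 `O=C([C@H]1CCCCN1)N1CCC2(CCN(c3nccc(NCc4ccc(Cl)cc4Cl)n3)CC2)C1` gives 172 ug/mL and compound 2 `O=C([C@@H]1CCCCN1)N1CCC2(CCN(c3nccc(NCc4ccc(Cl)cc4Cl)n3)CC2)C1` gives 170 ug/mL. Their configurations differ, and the step between them stays within the scatter: a 1.0-fold lower number from compound 1 to compound 2 (0.01 log units; within the scatter). Compound 3 `O=C(C1CCCCC1)N1CCC2(CCN(c3nccc(NCc4ccc(Cl)cc4Cl)n3)CC2)C1` gives 3 ug/mL, the lowest of the three numbers.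

The next structure is compound 4 `Clc1ccc(CNc2ccnc(N3CCC4(CCN(CC5CCCN5)C4)CC3)n2)c(Cl)c1`. The change is (pyrrolidin-2-yl)methyl in place of cyclohexylcarbonyl on an amine nitrogen in a ring. In words, (pyrrolidin-2-yl)methyl stands in place of cyclohexylcarbonyl on an amine nitrogen in a ring.

Among the measured compounds shown here, two measured steps bear on this change, both large: a 57-fold lower number from compound 1 to compound 3 (1.76 log units; beyond the scatter) and a 57-fold lower number from compound 2 to compound 3 (1.75 log units; beyond the scatter). Each puts cyclohexyl in place of piperidin-2-yl on a carbonyl carbon. Compound 4 runs the other way, with a carbon-only ring leaving and a ring with a hetero atom entering. The comparison is only partial, however. For the measured compounds named here, all three measured compounds keep the carbonyl, compound 4 lacks it, and no measured compound carries (pyrrolidin-2-yl)methyl.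

A large step to a higher number in this assay is therefore expected, possibly somewhat short of the two measured ones: a 43-fold higher number from compound 3 to compound 4 (1.64 log units; beyond the scatter). The estimate for compound 4 is 130 ug/mL, with an expected range of 40 ug/mL to 260 ug/mL.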

Compound 4, solubility: 270 ug/mL
Beside the measured number, compound 4's estimate is 2.1-fold (0.32 log units) below it, and the stated range ends below it.
By their numbers in this assay, from the lowest: compound 3; then compounds 2, 1 and 4 (each within the scatter of the next).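

In this assay, among the compounds shown here, the earlier compounds showed a large drop only with the carbonyl kept, and this result shows that the high numbers do not depend on that carbonyl: a 90-fold higher number from compound 3 to compound 4 (1.95 log units; beyond the scatter). Against the two compounds that carry (piperidin-2-yl)carbonyl at the same amine nitrogen, the steps are a 1.6-fold higher number from compound 2 to compound 4 (0.20 log units; within the scatter) and a 1.6-fold higher number from compound 1 to compound 4 (0.20 log units; within the scatter), so removing the carbonyl and changing the ring from piperidine to pyrrolidine together leave compound 4 level with compounds 1 and 2. Among these four compounds, those with a nitrogen in the ring of the group sit together and the carbon-only ring of compound 3 stands alone, with no compound against that pattern.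

Because compound 4 differs from compound 3 in ring and carbonyl at once, the compounds shown leave open whether cyclohexylmethyl, a carbon-only ring on the same nitrogen without the carbonyl, would stay near compound 3 or move towards compound 4. They also give no separate reading for (pyrrolidin-2-yl)carbonyl or (piperidin-2-yl)methyl, and nothing available here bears on the cause of these steps.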